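The compounds below may be only part of what the source reports. "The series", "measured", "known", "first", "only" and "open" are said of these compounds alone.

Among the compounds with values here, in a functional assay on MCF7 cells (Homo sapiens) for inhibition, read by MTT assay, with a stated time of 48 h (on this read-out lower numbers stand for stronger inhibition and higher numbers for weaker inhibition), compound 3 `COc1ccc(-n2cc(NC(=O)c3ccc(NS(=O)(=O)c4ccccc4)cc3)cn2)cc1` gives 25600 nM, the second highest of the three numbers measured so far. Compound 2 `O=C(Nc1cnn(-c2ccccc2)c1)c1ccc(NS(=O)(=O)c2ccccc2)cc1` gives 17100 nM, and the step of a 1.5-fold higher number from compound 2 to compound 3 (0.18 log units; within the scatter) stays within the scatter. Compound 1 `Cn1cc(NC(=O)c2ccc(NS(=O)(=O)c3ccccc3)cc2)cn1` gives 58700 nM; the steps of a 3.4-fold lower number from compound 1 to compound 2 (0.54 log units; beyond the scatter) and a 2.3-fold lower number from compound 1 to compound 3 (0.36 log units; beyond the scatter) are both modest but beyond the scatter. Compound 4 `COc1cccc(-n2cc(NC(=O)c3ccc(NS(=O)(=O)c4ccccc4)cc3)cn2)c1` differs from compound 3 in one change: 3-methoxyphenyl in place of 4-methoxyphenyl on an aromatic nitrogen. Within the data shown here, no measured step changes where the methoxy group sits; the only step that touches the methoxy, a 1.5-fold higher number from compound 2 to compound 3 (0.18 log units; within the scatter), lay within the scatter. The step of a 1.0-fold lower number from compound 3 to compound 4 (0.01 log units; within the scatter) is therefore expected to stay within the scatter. Compound 4 is estimated at 25000 nM, with a range from 10000 nM to 60000 nM.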

Compound 4, half-maximal inhibitory concentration: 28400 nM
Compound 4: the middle estimate sits 1.1-fold (0.06 log units) below what was measured; the measured number falls inside the stated range.
By their numbers in this assay, from the lowest: compounds 2, 3 and 4 (each within the scatter of the next); then compound 1.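

Moving the methoxy group on the phenyl ring is now tested directly in this assay: 3-methoxyphenyl in place of 4-methoxyphenyl gives a 1.1-fold higher number from compound 3 to compound 4 (0.05 log units; within the scatter), so neither position can be told apart from the other. Adding the methoxy to the plain phenyl gives a 1.7-fold higher number from compound 2 to compound 4 (0.22 log units; within the scatter), while replacing methyl with 3-methoxyphenyl still gives a 2.1-fold lower number from compound 1 to compound 4 (0.32 log units; beyond the scatter), so the difference from methyl holds at both methoxy positions. Nothing available explains these results. From the compounds shown here alone, it remains open whether an amine or a carboxylic acid on this ring would move the number beyond the scatter.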